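Trimming the side chain of compound 1

The compounds below may be only part of what the source reports. "The series", "measured", "known", "first", "only" and "open" are said of these compounds alone.

In a physicochemical assay for lipophilicity (on this read-out lower numbers stand for lower lipophilicity and higher numbers for higher lipophilicity), compound 1 (`CCCCCCCCCCCCCCOC(COCc1cccc(OC)c1)COc1ccc(-c2noc(=O)[nH]2)cc1`) gives 8.56 and compound 2 (`CCCCCCCCCCCCCCOC(COc1ccc(Cc2noc(=O)[nH]2)cc1)COc1ccc(Cc2noc(=O)[nH]2)cc1`) gives 7.64 as the lower number, a gap beyond the scatter. Compound 3 (`CCCCCCCCCCCCCCOC(COCC)COc1ccc(-c2noc(=O)[nH]2)cc1`) awaits measurement. It carries the change methyl in place of 3-methoxyphenyl on a saturated chain carbon bound to an oxygen on a saturated carbon on a saturated chain carbon bound to an oxygen on a saturated carbon, which also reads as 3-methoxybenzyl to ethyl. Within the data shown here, no measured step covers this change, so the expectation rests on the structures alone. A fall beyond the scatter is expected in this assay for the estimated step of a number 1.36 log units lower from compound 1 to compound 3 (beyond the scatter) as the smaller group enters. Compound 3 is estimated at 7.2 within an expected range from 6.6 to 7.8 once measured.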

Compound 3, partition coefficient: 7.34
Compound 3: the middle estimate sits 0.14 log units below what was measured, within the range that was stated.
By their numbers in this assay, from the lowest: compounds 3 and 2 (each within the scatter of the next); then compound 1.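

In this assay, methyl in place of 3-methoxyphenyl on a saturated chain carbon bound to an oxygen on a saturated carbon gives a number 1.22 log units lower from compound 1 to compound 3 (beyond the scatter) and the step is large. Among these compounds, this is the first measured single-place step, and it shows that the read-out responds strongly to this position with the rest of the structure unchanged. Nothing measured yet accounts for the size of this step.

From the compounds shown here alone, whether the step tracks the loss of the aromatic ring or the loss of heavy atoms stays open. A longer chain such as butyl, or an amine or a carboxylic acid, at this position would help separate the two.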